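Swapping methyl for chloro in compound 2

A few compounds are considered here, and "the series" means these few. Any claim that something is new, unique, unknown or untested is made for them only; others in the source may bear on it.

Compound 1 `Cc1ccc(C(Br)C(Br)c2ncc([N+](=O)[O-])n2C)cc1` gives 11200 nM
Compound 2 `Cc1cccc(/C=C/c2ncc([N+](=O)[O-])n2C)c1` gives 30900 nM
Compound 3 `Cc1cc(C)c(/C=C/c2ncc([N+](=O)[O-])n2C)c(C)c1` gives 11000 nM

In an ADME assay on HeLa cells (Homo sapiens) for cytotoxicity, read by resazurin assay, with a stated time of 2 days (on this read-out lower numbers stand for stronger inhibition and higher numbers for weaker inhibition), compound 2 has the highest number of the three. Compounds 1 and 3 both lie lower, and each gap is beyond the usual scatter. The compound still to be measured is compound 4 `Cn1c([N+](=O)[O-])cnc1/C=C/c1cccc(Cl)c1` which keeps the shared core of compound 2 and changes one place: chloro in place of methyl on an aromatic carbon meta to a large group. For the measured compounds named here, no measured pair here shows this single swap, so the data give no direct size for it. The expectation therefore rests on compound 2 (30900 nM) and stays close to it. Expected is a small step of a 1.2-fold lower number from compound 2 to compound 4 (0.09 log units; within the scatter) toward a lower number, one that stays within the usual scatter. Compound 4 is estimated at 25000 nM (expected range 10000 nM to 60000 nM).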

Compound 4, half-maximal inhibitory concentration: 30200 nM
The estimate for compound 4 lay 1.2-fold (0.08 log units) below the measured number; the measured number falls inside the stated range.
By their numbers in this assay, from the lowest: compounds 3 and 1 (each within the scatter of the next); then compounds 4 and 2 (each within the scatter of the next).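

In this assay, for the compounds shown here, chloro in place of methyl on an aromatic carbon meta to a large group gives a 1.0-fold lower number from compound 2 to compound 4 (0.01 log units; within the scatter), which is a direct size for this swap that the earlier compounds could not provide. At this position, the two groups cannot be told apart in this read-out, although a single pair cannot show whether that holds for the same swap elsewhere. Nothing available explains why the two groups read alike.

As far as these compounds go, it remains open whether a different kind of group at this same place, such as an amine, a carboxylic acid or a longer chain, would give a step beyond the usual scatter. From the compounds shown here alone, it is also open whether chloro in place of methyl would give a similar step on another core.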